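A few compounds are considered here, and "the series" means these few. Any claim that something is new, unique, unknown or untested is made for them only; others in the source may bear on it.

Of the compounds shown here, two have so far been tested in a physicochemical assay for solubility, at pH 6.8 (a higher number here means a more soluble compound, a lower number a less soluble compound), and only one gave a true number. Compound 1 `Nc1ccc(CNC(=O)Nc2ccc(CN3C(=O)c4ccccc4C3=O)cc2)cn1` is reported at < 5000 nM as a limit of the assay, not a number. Among the compounds with values here, compound 2 `C[C@H](NC(=O)[C@@H]1CCCN1C)c1ccc(NC(=O)[C@H]2C[C@@H]2c2cccnc2)cc1` gives 730000 nM as the only number available, so there is no other measured number to rank it against. Compound 3 `C[C@H](NC(=O)c1ncccn1)c1ccc(NC(=O)[C@H]2C[C@@H]2c2cccnc2)cc1` keeps the rest of compound 2 and carries pyrimidin-2-yl in place of 1-methylpyrrolidin-2-yl on a carbonyl carbon, the difference being pyrimidin-2-yl in place of 1-methylpyrrolidin-2-yl on a carbonyl carbon and nothing else. Within the data shown here, no measured pair shows what such a swap does, so any forecast here is loose. The one hint is thin: compound 1 also lacks 1-methylpyrrolidin-2-yl and sits at < 5000 nM as a limit. On that hint a clear fall, beyond the usual scatter, is expected, and the estimated 15-fold lower number from compound 2 to compound 3 (1.16 log units; beyond the scatter) is large but uncertain. For compound 3 the estimate is 50000 nM with 8000 nM to 300000 nM as the expected range.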

Compound 3, solubility: 27000 nM
Compound 3: middle estimate off by 1.9-fold (0.27 log units), on the high side; low and high end bracket the measured number.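

Within the data shown here, the first measured pair in this assay shows that the group on this carbonyl carbon can matter a great deal: with the rest of the molecule unchanged, pyrimidin-2-yl in place of 1-methylpyrrolidin-2-yl gives a 27-fold lower number from compound 2 to compound 3 (1.43 log units; beyond the scatter). The size of the group cannot separate the two, since leaving and entering groups both count the same number of heavy atoms; what changes is a five-membered non-aromatic ring with one hetero atom and a defined stereocentre, replaced by a six-membered aromatic ring with two hetero atoms and no stereocentre. Despite the large step, compound 3 gives a true number rather than a limit, so the full size of the step can be read: the limit of < 5000 nM in this assay, at which 1 of the 3 values shown sits.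

A single pair cannot tell which of these differences accounts for the step, or whether the same swap would have a similar effect on a different core. It also leaves open what an open-chain amine such as dimethylaminomethyl, a carboxylic acid or a simple phenyl ring would give on the same carbonyl carbon.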